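This account rests on a few compounds, and the source may have more. Where it says the series, first, only, none or still open, it means among the compounds named here.

In an assay on isolated protein (Oryctolagus cuniculus) with Thromboxane-A synthase (Homo sapiens) as the target, tested at 1 uM (a lower number here means less inhibition, a higher number more inhibition at the concentration tested (going by the name of the read-out)), compound 3 `COCCn1nc(-c2cccnc2)c2ccccc2c1=O` gives 55% and stands second highest of the three numbers shown. Compound 1 `O=c1c2ccccc2c(-c2cccnc2)nn1C1CCCC1` gives 97% in this assay, and compound 2 `CC(=O)Cn1nc(-c2cccnc2)c2ccccc2c1=O` gives 13%. The steps run a number 42 percentage points lower from compound 1 to compound 3 (beyond the scatter), a number 84 percentage points lower from compound 1 to compound 2 (beyond the scatter) and a number 42 percentage points higher from compound 2 to compound 3 (beyond the scatter). Compound 4 `CCOC(=O)CCCn1nc(-c2cccnc2)c2ccccc2c1=O` follows from compound 3 by one change: (ethoxycarbonyl)methyl in place of methoxy on a saturated chain carbon, two bonds along the chain from an aromatic nitrogen. The step of a number 42 percentage points higher from compound 2 to compound 3 (beyond the scatter) bears most on this, as compound 2 carries an acetyl and compound 4 again carries a carbonyl within its (ethoxycarbonyl)methyl, while a number 42 percentage points lower from compound 1 to compound 3 (beyond the scatter) shows how far chain groups on that nitrogen already trail the cyclopentyl. For compound 4 a further fall beyond the scatter is therefore expected, a number 25 percentage points lower from compound 3 to compound 4 (beyond the scatter), yet short of a full return to the level of compound 2. Compound 4 is estimated at 30%, within 10% to 55%.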

Compound 4, a percentage reported as inhibition, at one concentration (the size of the read-out at that concentration, not a potency): 95%
Estimate against measurement, compound 4: 65 percentage points below, and the stated range ends below it.
By their numbers in this assay, from the lowest: compound 2; then compound 3; then compounds 4 and 1 (each within the scatter of the next).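

In this assay, a chain group on the aromatic nitrogen can match the cyclopentyl: the data show a number 2 percentage points lower from compound 1 to compound 4 (within the scatter) with 3-(ethoxycarbonyl)propyl in its place, though compound 2 and compound 3 do not match it. A carbonyl in the chain does not in itself go with a low number, as the series runs a number 82 percentage points higher from compound 2 to compound 4 (beyond the scatter) and a number 40 percentage points higher from compound 3 to compound 4 (beyond the scatter) for the ester-bearing chain. Nothing measured here explains these steps.

On these data alone, whether the ester or the chain length carries the rise stays open. A carboxylic acid at the chain end, an amine or a longer chain would bear on this.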